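The source may hold more compounds than are shown below. What is called first, only, known or untested is meant among the compounds shown, and "the series" means these compounds.

Notes on the series. Compound 2, `COc1ccc(/C=C/S(=O)(=O)Nc2ccc(OC)cc2)cc1`, and compound 1, `COc1ccc(/C=C/S(=O)(=O)Nc2ccc(OC)c(F)c2)cc1`, share one core and differ only by fluoro in place of hydrogen on an aromatic carbon. In a functional assay on DU-145 cells (Homo sapiens) for cytotoxicity, read by trypan blue exclusion, with a stated time of 96 h (on this read-out lower numbers stand for stronger inhibition and higher numbers for weaker inhibition), compound 2 gives 5000 nM and compound 1 gives 5000 nM; the step is no change at the digits printed from compound 2 to compound 1 (within the scatter). Compound 3, `COc1ccc(NS(=O)(=O)/C=C/c2c(OC)cc(OC)cc2OC)cc1`, is built on another core; the difference between the two cores is not broken down here. In this assay compound 3 gives 200 nM, the lowest of the three numbers, and its gap to both compound 1 and compound 2 lies beyond the scatter.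

Compound 4, `COc1cc(OC)c(/C=C/S(=O)(=O)Nc2ccc(OC)c(F)c2)c(OC)c1`, is not yet measured. It stands to compound 3 as compound 1 stands to compound 2: the difference is fluoro in place of hydrogen on an aromatic carbon, and the surroundings of the place are described in the same words for both pairs, so this is the same change, made on the core of compound 3 instead of the core of compound 2. Among the four compounds the change occurs twice, once measured and once pending.

The measured instance, no change at the digits printed from compound 2 to compound 1 (within the scatter), left the number where it stood. Among the measured compounds shown here, nothing else bearing on this change is available, so the expected step for compound 4 in this assay is of the same size, no change at the digits printed from compound 3 to compound 4 (within the scatter), because the only precedent is no change at the digits printed from compound 2 to compound 1 (within the scatter). Starting from compound 3 at 200 nM, compound 4 is therefore expected to give about 200 nM, with a range from 90 nM to 450 nM.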

Compound 4, half-maximal inhibitory concentration: 200 nM
Beside the measured number, compound 4's estimate shows no gap at the digits printed, and the stated range covers the measured number.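

Notes on the fluoro step. In this assay, fluoro in place of hydrogen on the core of compound 3 gives no change at the digits printed from compound 3 to compound 4 (within the scatter), and this step agrees with the one seen earlier on the core of compound 2: the same change on two cores in this assay, no change at the digits printed (within the scatter) from compound 2 to compound 1 and no change at the digits printed (within the scatter) from compound 3 to compound 4, 1.0-fold (0.00 log units) apart, within the scatter of two such steps. Within this series, then, the change carries from one core to the other as a silent step: in both matched pairs, the 4-methoxyphenyl to 3-fluoro-4-methoxyphenyl swap leaves the printed number where it stood. Among the compounds shown here, this rests on only two pairs, one place on the ring and one cell assay, so it does not show that the step would stay silent on any further core or in any other read-out, and a step of no size gives no account of what the fluoro does or of why the number holds.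

The compounds shown leave open whether another group at the same place, such as chloro, trifluoromethyl, an amine or a carboxylic acid, would also leave the number unmoved on either core. They also leave open whether the methoxy group that the fluoro sits ortho to could give way to a longer chain, such as ethoxy or propoxy, with the same outcome on both cores.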